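Adding a Methoxy Group to Three Inactive Compounds

The source may hold more compounds than are shown below. What is called first, only, known or untested is meant among the compounds shown, and "the series" means these compounds.

Measured in a functional assay on MDA-MB-231 cells (Homo sapiens) for cytotoxicity, read by MTT assay, with a stated time of 72 h; on this read-out higher numbers stand for weaker inhibition and lower numbers for stronger inhibition:
compound 1 `COc1ccc(-c2cc(/N=C3/NC(=O)CS3)cs2)cc1` gives > 50000 nM, a limit of the assay.
compound 2 `O=C1CS/C(=N\c2csc(-c3ccccc3)c2)N1` gives > 50000 nM, a limit of the assay.
compound 3 `COc1cccc(N2C(=O)CS/C2=N\c2csc(-c3ccc(Cl)cc3)c2)c1` gives > 50000 nM, a limit of the assay.

Compound 2 and compound 1 differ in one place, (methoxy in place of hydrogen on an aromatic carbon), and the step that the two limits leave unreadable from compound 2 to compound 1 cannot be sized since both values sit at the limit (the limit of > 50000 nM in this assay, at which 3 of the 3 values shown sit). The difference between the cores of compound 2 and compound 3 is not broken down here. Compound 4 `COc1ccc(N2C(=O)CS/C2=N\c2csc(-c3ccc(Cl)cc3)c2)cc1OC` is not yet measured; it differs from compound 3 by methoxy in place of hydrogen on an aromatic carbon. This is the same kind of change as from compound 2 to compound 1, though the place is not identical: in compound 4 the entering group sits ortho to a methoxy group, whereas in compound 1 it sits only para to a large group. Since the earlier step that the two limits leave unreadable from compound 2 to compound 1 was unreadable and every value shown sits at the limit (the limit of > 50000 nM in this assay, at which 3 of the 3 values shown sit), for compound 4 the expected step is a step that the limit leaves unreadable from compound 3 to compound 4. Compound 4 is therefore estimated at 60000 nM in this assay, most likely again only a limit.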

Compound 4, half-maximal inhibitory concentration: 46900 nM
For compound 4 the middle estimate is 1.3-fold (0.11 log units) above the measured one; measured number inside the range.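

In this assay, putting methoxy in place of hydrogen on an aromatic carbon gives an at least 1.0-fold lower number from compound 3 to compound 4 (0.02 log units; that floor lies within the scatter), so this step shows no gain beyond the usual scatter of the measurement, although its true size could be larger. It does not show that the change acts in the same way on both cores, and it does not show that the change makes a compound more active. The step from compound 2 to compound 1 cannot be read, so the two steps cannot be compared, because nearly all the values are limits: the limit of > 50000 nM in this assay, at which 3 of the 4 values shown sit.

The compounds shown leave open whether an amine or a carboxylic acid at the same place would give a clearly stronger value. They also leave open whether methoxy at another place on the ring would do so.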